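Rhodanine-type arylidenes: growth inhibition on lung carcinoma cells

A few compounds are considered here, and "the series" means these few. Any claim that something is new, unique, unknown or untested is made for them only; others in the source may bear on it.

Measured so far:
compound 1 `O=C1NC(=S)/C(=C/c2ccc(Br)cc2)S1`: 36.5%
compound 2 `O=C1NC(=S)/C(=C/c2ccccc2Br)S1`: 36.9%

The two compounds share one core and differ only in where the bromo sits on the phenyl ring. In a functional assay on NCI-H292 cells (Homo sapiens) for cytotoxicity, read by MTT assay, with a stated time of 72 h, tested at 10 ug/mL (a higher number here means more inhibition of growth at the concentration tested, a lower number less inhibition of growth), compound 1 gives 36.5%, the lower of the two numbers, with compound 2 at 36.9%, a gap that lies within the scatter of this kind of measurement. On these numbers compound 1 and compound 2 cannot be told apart.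

Compound 3 `O=C1NC(=S)/C(=C/c2ccc(F)cc2)S1` has not been measured. Its difference from compound 1 is fluoro in place of bromo on an aromatic carbon. Among the measured compounds shown here, no step between measured compounds covers a halogen swap of this kind, so the size of the step in this assay is open. Given that moving the bromo around the ring left the number where it was, the expectation is a step from compound 1 to compound 3 of about a number 4.5 percentage points lower from compound 1 to compound 3 (within the scatter), small and probably not beyond the scatter, if anything toward less inhibition.

Compound 3 is thus estimated at 32% in this assay, expected to fall between 18% and 48%.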

Compound 3, percent growth inhibition at one concentration: 38%
The estimate for compound 3 lay 6 percentage points below the measured number, and the stated range covers the measured number.
By their numbers in this assay, from the lowest: compounds 1, 2 and 3 (each within the scatter of the next).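

In this assay, fluoro in place of bromo on an aromatic carbon, para to a group of 8 heavy atoms, gives a step of a number 1.5 percentage points higher from compound 1 to compound 3 (within the scatter). The earlier pair covered only a shift of the bromo around the phenyl ring, whereas this step changes the identity of the halogen at a fixed place, and that exchange also gives no readable difference in growth inhibition at the single concentration tested. No measurement shown here bears on why the number holds across this exchange, so the result stands as an observation on this one pair and offers no explanation.

The compounds shown leave open whether this place on the ring responds to anything other than a halogen, such as an amine, a carboxylic acid, a methoxy group or a longer alkyl chain, any of which would test it more widely than bromo and fluoro can. Also open, as far as these compounds go, is how the phenyl ring with no substituent at all would read in this assay, and whether changes on the shared core itself would move the number when the halogen exchange does not.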